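Nitro-sulfonyl amide series: no measurable receptor inhibition so far

The source may report more compounds than this note shows. Statements on the series, on what has been measured and on what is new or still open speak of the compounds shown alone.

compound 1 `CS(=O)(=O)c1ccc(C(=O)N2CCC(C(=O)N(Cc3ccccc3)c3ccccc3)CC2)cc1[N+](=O)[O-]` — > 60000 nM
compound 2 `CN(Cc1ccccc1)C(=O)CNC(=O)c1ccc(S(C)(=O)=O)c([N+](=O)[O-])c1` — > 60000 nM
compound 3 `CS(=O)(=O)c1ccc(C(=O)NCCCC(=O)N2Cc3ccccc3C2)cc1[N+](=O)[O-]` — > 60000 nM

In an assay on isolated protein for inhibition of thyroid hormone receptor alpha (Homo sapiens), read by fluorescence polarization (on this read-out lower numbers stand for stronger inhibition and higher numbers for weaker inhibition), compound 1 returns only a limit, > 60000 nM, and no number. Compound 2 likewise sits at a limit, > 60000 nM. Compound 3 also gives only a limit, > 60000 nM. All three values rest on (the limit of > 60000 nM in this assay, at which 3 of the 3 values shown sit), so compound 1 cannot be ranked against the others; it simply stands at the limit of this assay with them.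

Compound 4, `CS(=O)(=O)c1ccc(C(=O)N2CCC(C(=O)N(Cc3ccccc3)Cc3ccccc3)CC2)cc1[N+](=O)[O-]`, is not yet measured. It differs from compound 1 by benzyl in place of phenyl on an amide-type nitrogen. Among the measured compounds shown here, no step between measured compounds is available to guide the size of this change. The step that the limit leaves unreadable from compound 1 to compound 4 is expected to lie within the scatter, with the result most likely again reported as a limit. For compound 4 the estimate is 80000 nM, ranging from 30000 nM to 300000 nM.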

Compound 4, half-maximal inhibitory concentration: > 60000 nM
Compound 4 was reported as a limit; the forecaster's own chance of this, stated with the estimate: 85%; the middle value is on the limit's open side.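

No step can be read between compound 1 and compound 4, since both stand only as limits: the limit of > 60000 nM in this assay, at which 4 of the 4 values shown sit.

The compounds shown leave open which change to the shared core, if any, would give a number in this assay rather than a limit.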